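Cytotoxicity notes: benzyl variation on the imidazole series

A few compounds are considered here, and "the series" means these few. Any claim that something is new, unique, unknown or untested is made for them only; others in the source may bear on it.

Compound 1 `COC(=O)c1ccc(NCc2cncn2Cc2ccc(Cl)cc2)cc1-c1ccccc1` in a toxicity assay on NIH3T3 cells (Mus musculus) for cytotoxicity, read by resazurin assay (a higher number here means that more compound is needed for the effect, a lower number that less compound is needed), gives 25000 nM. Compound 2 `COC(=O)c1ccc(NCc2cncn2Cc2ccc(OC)cc2)cc1-c1ccccc1` in this assay gives "not determined" (no result reported). Compound 3 `COC(=O)c1ccc(NCc2cncn2Cc2ccc(F)cc2F)cc1-c1ccccc1` in this assay gives > 1000 nM, a limit of the assay rather than a number. Compound 3 thus stands only at that limit, which is also where the limit of > 1000 nM in this assay, at which 1 of the 3 values shown sits, places it among the three values. The step that the limit leaves unreadable from compound 1 to compound 3 is therefore unreadable in size. Compound 4 `COC(=O)c1ccc(NCc2cncn2Cc2ccccc2C)cc1-c1ccccc1` carries 2-methylphenyl in place of 2,4-difluorophenyl on a saturated chain carbon bound to an aromatic nitrogen. Within the data shown here, no measured step bears on this change in a readable way, so no direction can be expected beyond the scatter. Compound 4 is expected in this assay at 20000 nM, between 5000 nM and 60000 nM. The step that the limit leaves unreadable from compound 3 to compound 4 is likewise an estimate only.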

Compound 4, half-maximal effective concentration: 10000 nM
Compound 4: the middle estimate sits 2.0-fold (0.30 log units) above what was measured, and the stated range covers the measured number.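

In this assay, among these compounds, the change to 2-methylphenyl gives a 2.5-fold lower number from compound 1 to compound 4 (0.40 log units; beyond the scatter) as the first readable step at this position, on a saturated chain carbon bound to an aromatic nitrogen, so the group placed here can shift the number. Both steps involving compound 3 cannot be read, and its value remains a limit: the limit of > 1000 nM in this assay, at which 1 of the 4 values shown sits.

The compounds shown leave open whether a step of similar size follows from other groups at this place, such as a carboxylic acid or an amine. They also leave open whether a longer chain would change the number.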